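Adding a methoxy group to compound 2

The source may report more compounds than this note shows. Statements on the series, on what has been measured and on what is new or still open speak of the compounds shown alone.

Compound 1 `COc1ccc2c(=O)cc(-c3ccccc3)sc2c1` gives 9.16 ug/mL here
Compound 2 `COc1cc2sc(-c3ccccc3)cc(=O)c2cc1OC` gives 9.33 ug/mL here
Compound 3 `O=c1cc(-c2ccccc2)sc2cc(O)c(O)cc12` gives 1.45 ug/mL here

These numbers come from a functional assay on HCT-8 cells (Homo sapiens) (a higher number here means that more compound is needed for the effect, a lower number that less compound is needed), and they form two levels. Compound 1 and compound 2 sit together at the high end, within the scatter of each other, while compound 3 stands well below both, so less of it is needed for the effect.

Compound 4 `COc1cccc(-c2cc(=O)c3cc(OC)c(OC)cc3s2)c1` has not yet been measured. The change from compound 2 is methoxy in place of hydrogen on an aromatic carbon and it amounts to methoxy in place of hydrogen on an aromatic carbon, meta to a large group. Among the measured compounds shown here, one measured step bears on this, the same kind of swap made in a different place, and it shows a 1.0-fold higher number from compound 1 to compound 2 (0.01 log units; within the scatter) in this assay with no real shift. A single example in another place is only a weak guide, and compound 3 shows that values in this set can differ clearly, so the range stays wide. The estimate is a 1.2-fold lower number from compound 2 to compound 4 (0.07 log units; within the scatter) as the expected step, which means no shift beyond the scatter is expected. Compound 4 is estimated at 8 ug/mL as a middle value, with an expected range from 3 ug/mL to 18 ug/mL for the measurement.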

Compound 4, concentration for half-maximal effect: 6.35 ug/mL
Beside the measured number, compound 4's estimate is 1.3-fold (0.10 log units) above it; low and high end bracket the measured number.
By their numbers in this assay, from the lowest: compound 3; then compounds 4, 1 and 2 (each within the scatter of the next).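

In this assay, methoxy in place of hydrogen on an aromatic carbon of a six-membered aromatic ring of carbon only, meta to a large group, gives a 1.5-fold lower number from compound 2 to compound 4 (0.17 log units; within the scatter), so the added group produces no shift that can be told apart from ordinary repeat variation. Alongside a 1.0-fold higher number from compound 1 to compound 2 (0.01 log units; within the scatter), this makes two different places in these compounds where the same swap stays within the scatter, although two steps are too few to support a rule for the whole series. No measurement is available that would give a reason for this result at the new position.

Going by these compounds, it remains open whether a different kind of group at this position, such as an amine, a carboxylic acid or a longer chain, would also leave the number within the scatter or would move it clearly. The compounds shown also leave open whether methoxy on the other carbons of this ring would behave in the same way, since this single step speaks only for the one position tested.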